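The compounds below may be only part of what the source reports. "The series", "measured", "known", "first", "only" and "open" are said of these compounds alone.

Measured so far:

Compound 1, `CCCCc1nc(=O)c(S(=O)(=O)c2ccc(-c3ccnc(NC(=O)C4CC4)c3)cc2)c(O)n1-c1c(OC)cccc1OC`: 183 nm/s
Compound 2, `CCCCc1[nH]c(=O)c(S(=O)(=O)c2ccc(-n3cc(Cl)ccc3=O)cc2)c(O)c1-c1c(OC)cccc1OC`: 285 nm/s

Both numbers come from an ADME assay for permeability, using PAMPA, at pH 5.5; on this read-out lower numbers stand for lower permeability and higher numbers for higher permeability. Compound 1 has the lower of the two numbers, but the gap to compound 2 lies within the scatter, so the two compounds cannot be told apart on this read-out.

Compound 3, `CCCCc1nc(=O)c(S(=O)(=O)c2ccc(C)cc2)c(O)n1-c1c(OC)cccc1OC`, has not yet been measured in this assay. It shares its core with compound 1 and differs in one place: methyl in place of 2-((cyclopropylcarbonyl)amino)pyridin-4-yl on an aromatic carbon. Among the measured compounds shown here, no measured pair in this set shows what such a change does, so the expectation rests only on the size of the change itself, which removes a large group and puts a single carbon in its place.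

For compound 3 the expected step of a 2.7-fold higher number from compound 1 to compound 3 (0.44 log units; beyond the scatter) in this assay is upward and somewhat beyond the scatter. Compound 3 is therefore estimated at 500 nm/s, with a range from 200 nm/s to 1200 nm/s.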

Compound 3, apparent permeability: 243 nm/s
Compound 3: middle estimate off by 2.1-fold (0.31 log units), on the high side; measured number inside the range.
By their numbers in this assay, from the lowest: compounds 1, 3 and 2 (each within the scatter of the next).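

In this assay, the swap of 2-((cyclopropylcarbonyl)amino)pyridin-4-yl for methyl on this aromatic carbon gives a 1.3-fold higher number from compound 1 to compound 3 (0.12 log units; within the scatter) and so cannot be told apart from no change at all, even though 12 heavy atoms, two rings' worth of structure at most reduced to none, leave and a single carbon enters. Among the compounds shown here, this is the first step in the set that isolates this position, and it shows that, on the core of compound 1, the read-out does not separate a large group carrying a hydrogen-bond donor and acceptors from a plain methyl. No measurement available here explains this result.

A single pair cannot say how other groups on this carbon would behave, for example a carboxylic acid, a primary amine or a longer alkyl chain, or whether any of them would move the number beyond the scatter. It also leaves open whether the same swap would give a similarly small step on a core other than that of compound 1.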